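A few compounds are considered here, and "the series" means these few. Any claim that something is new, unique, unknown or untested is made for them only; others in the source may bear on it.

Working notes on the series.

Compound 1 `Cc1c(F)ccc(C(=O)Nc2cc(C(=O)Oc3ccccc3)ccc2N2CCN(C)CC2)c1Cl` has the lower of the two numbers recorded so far in an ADME assay for permeability, using PAMPA, with a stated time of 4 h; a lower number here means that the compound crosses the layer more slowly, a higher number that the compound crosses the layer faster: compound 1 gives 48 10^-6 cm/s. Compound 2 `CC(C)OC(=O)c1ccc(N2CCN(C)CC2)c(NC(=O)c2ccc(F)c([N+](=O)[O-])c2)c1` differs from compound 1 in several places; in this assay compound 2 gives 61.4 10^-6 cm/s. The two values sit within the scatter of each other, so the figures show no order between compound 1 and compound 2.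

Compound 3 `Cc1c(F)c(N)cc(C(=O)Nc2cc(C(=O)Oc3ccccc3)ccc2N2CCN(C)CC2)c1Cl` is compound 1 with one change: amino in place of hydrogen on an aromatic carbon. Among the measured compounds shown here, no measured pair carries this change, so the size of the step is open. The expectation is a modest fall in this assay, of a size that may or may not clear the scatter, so the step from a 1.6-fold lower number from compound 1 to compound 3 (0.20 log units; within the scatter) is estimated as small and downward. For compound 3 the estimate in this assay is 30 10^-6 cm/s, with a range from 15 10^-6 cm/s to 55 10^-6 cm/s.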

Compound 3, apparent permeability: 38 10^-6 cm/s
For compound 3 the middle estimate is 1.3-fold (0.10 log units) below the measured one, and the stated range covers the measured number.
By their numbers in this assay, from the lowest: compounds 3, 1 and 2 (each within the scatter of the next).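

Among the compounds shown here, this is the first step that differs in one place: amino in place of hydrogen on an aromatic carbon, ortho to a fluoro group and para to a chloro group, gives in this assay a 1.3-fold lower number from compound 1 to compound 3 (0.10 log units; within the scatter). At this position, therefore, the change from 2-chloro-4-fluoro-3-methylphenyl to 5-amino-2-chloro-4-fluoro-3-methylphenyl puts no order between the two compounds, and a single added nitrogen here has no effect that can be read beyond the scatter. Nothing measured on the series bears on why the step has this size.

As far as these compounds go, whether a hydroxyl, a methoxy group or a dimethylamino group at the same position would give a step beyond the scatter stays open. From the compounds shown here alone, it is also open whether amino here gives a similar step when an isopropyl ester replaces the phenyl ester.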